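Cyclopentyl for methylcyclohexyl on the amide nitrogen: expected cytotoxicity

A few compounds are considered here, and "the series" means these few. Any claim that something is new, unique, unknown or untested is made for them only; others in the source may bear on it.

Measured compounds:
compound 1, `CC1CCCCC1N(CCCCCCN1C[C@H](O)[C@@H](O)[C@H](O)[C@H]1CO)C(=O)C(C)(C)C`; in an ADME assay on Huh-7 cells (Homo sapiens) for cytotoxicity, read by MTT assay (on this read-out lower numbers stand for higher toxicity in this test and higher numbers for lower toxicity in this test), compound 1 gives 310000 nM.
compound 2, `CC(C)(C)C(=O)N(CCCCCCN1C[C@H](O)[C@@H](O)[C@H](O)[C@H]1CO)c1ccc(F)cc1F`; in this assay compound 2 stops at a limit of the assay, > 500000 nM.
compound 3, `CC(C)(C)C(=O)N(CCCCCCN1C[C@H](O)[C@@H](O)[C@H](O)[C@H]1CO)c1cc(F)ccc1F`; in this assay compound 3 likewise stops at a limit of the assay, > 500000 nM.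

Compound 1 is the only one of the three to return an actual number in this assay. Compound 2 and compound 3 both sit at the limit of > 500000 nM in this assay, at which 2 of the 3 values shown sit, so compound 1 stands as the sole fixed point against which the others are read.

Compound 4, `CC(C)(C)C(=O)N(CCCCCCN1C[C@H](O)[C@@H](O)[C@H](O)[C@H]1CO)C1CCCC1`, differs from compound 1 in one place: cyclopentyl in place of 2-methylcyclohexyl on an amide-type nitrogen. The measured steps that touch this same position are an at least 1.6-fold higher number from compound 1 to compound 2 (0.20 log units; that floor lies within the scatter) and an at least 1.6-fold higher number from compound 1 to compound 3 (0.20 log units; that floor lies within the scatter); each runs toward the limit, and neither is large enough to clear the scatter. The remaining step, a step that the two limits leave unreadable from compound 2 to compound 3, gives nothing readable. Two steps from the same starting point that stay within the scatter leave no basis for expecting a step beyond it here.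

Compound 4 is therefore expected to show a 1.3-fold higher number from compound 1 to compound 4 (0.11 log units; within the scatter), a shift that is not expected to clear the scatter and may amount to no change at all. Compound 4 is estimated at 400000 nM, with a range from 200000 nM to 800000 nM.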

Compound 4, half-maximal cytotoxic concentration: > 500000 nM
Compound 4: a limit, no number; the forecaster's own chance of this, stated with the estimate: 40%; middle value at least 1.2-fold (0.09 log units) away from the limit.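

In this assay compound 4 gives > 500000 nM, which is a limit of the assay and not a number. Among the compounds shown here, the one readable step is an at least 1.6-fold higher number from compound 1 to compound 4 (0.20 log units; that floor lies within the scatter), so the size of this change stays unknown, and the steps among compound 2, compound 3 and compound 4 cannot be read. What compound 4 adds is that the limit is not confined to the difluorophenyl groups: cyclopentyl, a non-aromatic ring of carbon only, reaches it on the same amide-type nitrogen, which leaves compound 1, with its 2-methylcyclohexyl, as the only compound of the four that returns a number, and the assay cannot rank the other three: the limit of > 500000 nM in this assay, at which 3 of the 4 values shown sit.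

The compounds shown leave open whether the number for compound 1 goes with the methyl group or with the six-membered ring, a question that a plain cyclohexyl on this nitrogen would address. They also leave open what actual values lie behind the limits of compound 2, compound 3 and compound 4, and whether a group carrying an amine or a carboxylic acid at this place would return a number in this assay.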